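Styryl tail versus biaryl tail: projecting compound 3

The source may report more compounds than this note shows. Statements on the series, on what has been measured and on what is new or still open speak of the compounds shown alone.

Two compounds of the shared core have numbers in an assay on isolated protein with Bile acid receptor (Homo sapiens) as the target; a higher number here means that more compound is needed for the effect, a lower number that less compound is needed. Compound 1 `COC(=O)/C=C/c1cccc(N(Cc2ccc(/C=C/c3ccccc3F)cc2)C(=O)C2CCCCC2)c1` gives 64 nM. Compound 2 `COC(=O)/C=C/c1cccc(N(Cc2ccc(-c3ccc(SC)cc3)cc2)C(=O)C2CCCCC2)c1` gives 69 nM; the two values sit within the scatter of each other, as the step of a 1.1-fold higher number from compound 1 to compound 2 (0.03 log units; within the scatter) shows, so no ranking between them can be drawn. Compound 3 `COC(=O)/C=C/c1cccc(N(Cc2ccc(/C=C/c3c(Cl)cccc3Cl)cc2)C(=O)C2CCCCC2)c1` is the next candidate; it carries 2-(2,6-dichlorophenyl)ethenyl in place of 4-(methylsulfanyl)phenyl on an aromatic carbon. Among the compounds with values here, only the step from compound 1 to compound 2 bears on this change, and it shows that swapping the terminal group between a biaryl type and a styryl type left the number unchanged. Compound 3 returns to the styryl type of compound 1, with chlorine in place of fluorine. For compound 3 the expected step is therefore a 1.2-fold lower number from compound 2 to compound 3 (0.06 log units; within the scatter), none beyond the scatter. The estimate for compound 3 in this assay is 60 nM, within a range of 25 nM to 150 nM.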

Compound 3, half-maximal effective concentration: 150 nM
Estimate against measurement, compound 3: 2.5-fold (0.40 log units) below, within the range that was stated.
By their numbers in this assay, from the lowest: compounds 1 and 2 (each within the scatter of the next); then compound 3.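

In this assay the terminal ring of the styryl tail matters: 2,6-dichlorophenyl in place of 2-fluorophenyl gives a 2.3-fold higher number from compound 1 to compound 3 (0.37 log units; beyond the scatter) and so opens the first gap beyond the scatter in the series. Against the biaryl tail, the change gives a 2.2-fold higher number from compound 2 to compound 3 (0.34 log units; beyond the scatter) and so the match within the scatter seen earlier between 4-(methylsulfanyl)phenyl and 2-(2-fluorophenyl)ethenyl does not carry over to 2-(2,6-dichlorophenyl)ethenyl.

Open, as far as these compounds go, is whether this step follows the chlorine atoms themselves or the second substituent on the ring, a question that a 2-chlorophenyl or a 2,6-difluorophenyl tail would separate. Also open, from the compounds shown here alone, is whether the same order of tails holds with a carboxylic acid in place of the methyl ester.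

No supporting measurement bears on the reason for these steps.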